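This account rests on a few compounds, and the source may have more. Where it says the series, first, only, none or still open, it means among the compounds named here.

In a functional assay on HaCaT cells (Homo sapiens) for antiproliferative activity, read by sulforhodamine B assay, with a stated time of 3 days (a higher number here means a weaker inhibitor, a lower number a stronger inhibitor), the measured compounds are:
compound 1 `COC(=O)c1cc(CCc2ccccc2OC)ccc1O`: 20000 nM
compound 2 `COC(=O)c1cc(CCc2cccc(OC)c2OC)ccc1O`: 33000 nM
compound 3 `COC(=O)c1cc(CCc2cc(N(C)C)ccc2OC)ccc1O`: 920 nM

Compound 1 stands at the high end of these numbers, level with compound 2 within the scatter and far from compound 3. Compound 4 `CCc1cccc(OC)c1CCc1ccc(O)c(C(=O)OC)c1` differs from compound 1 by one change: ethyl in place of hydrogen on an aromatic carbon. This is ethyl in place of hydrogen on an aromatic carbon, ortho to a large group and meta to a methoxy group. For the measured compounds named here, two measured steps bear on it. The methoxy step was small, a 1.7-fold higher number from compound 1 to compound 2 (0.22 log units; within the scatter), while the dimethylamino step was large, a 22-fold lower number from compound 1 to compound 3 (1.34 log units; beyond the scatter). Ethyl, like methoxy, brings no nitrogen, so compound 2, at 33000 nM, is taken as the nearer guide. No step beyond the scatter is therefore expected in this assay, and no firm direction. The expected step is a 1.1-fold lower number from compound 1 to compound 4 (0.05 log units; within the scatter). Compound 4 is estimated at 18000 nM, with an expected range from 6000 nM to 45000 nM.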

Compound 4, half-maximal inhibitory concentration: 200 nM
The estimate for compound 4 lay 90-fold (1.95 log units) above the measured number; measured number below the stated range.
By their numbers in this assay, from the lowest: compound 4; then compound 3; then compounds 1 and 2 (each within the scatter of the next).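

In this assay, ethyl on this aromatic carbon, ortho to a large group and meta to a methoxy group, gives a 100-fold lower number from compound 1 to compound 4 (2.00 log units; beyond the scatter). A large step on this ring therefore does not require nitrogen, since ethyl brings only carbon and no hydrogen-bond donors or acceptors. Nothing shown explains the size of this step. The compounds shown leave open whether a methyl group or a longer chain on this same carbon would give a step of similar size. They also leave open what an amine or a carboxylic acid would do there.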